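This account rests on a few compounds, and the source may have more. Where it says the series, first, only, none or still open, it means among the compounds named here.

For the measured compounds named here, of the two compounds measured so far, compound 2 `COc1ncc(C(F)(F)F)cc1CO[C@H]1[C@H](C(C)(C)C)[C@@H](C(=O)O)N(C(=O)[C@@H]2CCCCO2)[C@H]1c1ccccc1C1CC1` stands lower: in an assay on cells with Cystic fibrosis transmembrane conductance regulator variant F508del (Homo sapiens) as the target, read by voltage clamp, with a stated time of 24 h, in the presence of a further agent that is not named here (on this read-out lower numbers stand for smaller maximal responses and higher numbers for larger maximal responses), compound 2 gives 610%, whereas compound 1 `COc1ncc(C(F)(F)F)cc1CO[C@H]1[C@H](C(C)(C)C)[C@@H](C(=O)O)N(C(=O)[C@@H]2CCCCO2)[C@H]1c1ccccc1` gives 720%. Compound 3 `CCc1ccccc1[C@H]1[C@@H](OCc2cc(C(F)(F)F)cnc2OC)[C@H](C(C)(C)C)[C@@H](C(=O)O)N1C(=O)[C@@H]1CCCCO1` differs from compound 2 by ethyl in place of cyclopropyl on an aromatic carbon. Going by the values given here, only one measured step bears on this change, the step of a number 110 percentage points lower from compound 1 to compound 2 (beyond the scatter) at the same aromatic carbon, which shows that a group entering at this place lowered the maximal response by a large amount. Ethyl is a smaller group than cyclopropyl by the counts given and stands between hydrogen and cyclopropyl in that respect, so on the strength of a number 110 percentage points lower from compound 1 to compound 2 (beyond the scatter) compound 3 is expected to fall between compound 2 and compound 1 rather than outside them. The step of a number 50 percentage points higher from compound 2 to compound 3 (beyond the scatter) is therefore estimated as a modest rise, possibly within the scatter. The estimate for compound 3 in this assay is 660%, with a range from 540% to 780%.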

Compound 3, largest response reached (Emax), in percent of the reference or control that the assay uses: 490%
For compound 3 the middle estimate is 170 percentage points above the measured one; measured number below the stated range.
By their numbers in this assay, from the lowest: compound 3; then compound 2; then compound 1.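

In this assay the response at this aromatic carbon, ortho to a large group, does not follow the size of the group: the change from cyclopropyl to the smaller ethyl gives a number 120 percentage points lower from compound 2 to compound 3 (beyond the scatter), not a return towards the hydrogen of compound 1. Ethyl in place of hydrogen gives a number 230 percentage points lower from compound 1 to compound 3 (beyond the scatter), a larger drop than cyclopropyl produced at the same carbon, so among these three groups the one with the middle heavy-atom count gives the lowest number. Nothing measured here explains why ethyl lowers the maximal response further than cyclopropyl.

The compounds shown leave open where methyl, isopropyl or a longer chain such as propyl would stand at this carbon, and so whether the low number is peculiar to ethyl. They also leave open how a methoxy group or an amine would behave there.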